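This account rests on a few compounds, and the source may have more. Where it says the series, first, only, none or still open, it means among the compounds named here.

Notes on the series in an ADME assay on microsomes from liver (Rattus norvegicus, strain Sprague-Dawley) for pharmacokinetics, read by LC-MS, using NADPH, with a stated time of 45 min, tested at 1 uM (a lower number here means slower removal, a higher number faster removal of the compound), starting from compound 2 (`COc1cc(OCc2ccnc(N)n2)cc2sc(N[C@H]3CCCC[C@@H]3O)nc12`). Compound 2 gives 20 mL/min/kg and its mirror image, compound 1 (`COc1cc(OCc2ccnc(N)n2)cc2sc(N[C@@H]3CCCC[C@H]3O)nc12`), gives 24 mL/min/kg, so the two sit together at the low end of the three numbers. Compound 3 (`COc1cc(OCc2ccnc(N)n2)c(Cl)c2sc(N[C@H]3CCCC[C@@H]3O)nc12`) stands apart at 43 mL/min/kg.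

The next structure is compound 4 (`COc1cc(OCc2ccnc(Nc3cnoc3)n2)cc2sc(N[C@H]3CCCC[C@@H]3O)nc12`), which carries this change: 1,2-oxazol-4-yl in place of hydrogen on a nitrogen on an aromatic ring. Neither measured step touches that nitrogen, so both serve only as a rough guide to size. Inverting the stereocentres gives a 1.2-fold lower number from compound 1 to compound 2 (0.08 log units; within the scatter), with the fact that compounds 1 and 2 differ only in the configuration as drawn as the only structural difference. Chloro in place of hydrogen on an aromatic carbon gives a 2.2-fold higher number from compound 2 to compound 3 (0.33 log units; beyond the scatter), the one step so far beyond the scatter. On the strength of that step from compound 2 to compound 3, a modest rise is expected rather than a large one, though a result within the scatter would not surprise. The expected move is a 1.5-fold higher number from compound 2 to compound 4 (0.18 log units; within the scatter). For compound 4 the estimated clearance is 30 mL/min/kg, with an expected range of 14 mL/min/kg to 62 mL/min/kg.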

Compound 4, clearance: 87 mL/min/kg
For compound 4 the middle estimate is 2.9-fold (0.46 log units) below the measured one, outside the stated range (above it).
By their numbers in this assay, from the lowest: compounds 2, 1 and 3 (each within the scatter of the next, the first and the last beyond it); then compound 4.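

In this assay, going by these compounds alone, the earlier steps left this nitrogen untouched, so this is the first reading of a substituent at that place: the change from amino to (1,2-oxazol-4-yl)amino gives a 4.4-fold higher number from compound 2 to compound 4 (0.64 log units; beyond the scatter). The free amino group is therefore not a silent position in this assay, since replacing one of its hydrogens with a five-membered aromatic ring moves the number upward, beyond the scatter. Compound 4 also ranks above all three earlier compounds, although only its step from compound 2 is a single-place comparison.

A single substituent cannot show whether the rise belongs to 1,2-oxazol-4-yl itself or to any group on this nitrogen, and a methyl or acetyl group there would separate those two readings. Nothing measured here bears on why the number rises.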